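Swapping a cyclopropylsulfonyl for a tolylsulfonyl on compound 2

The compounds below may be only part of what the source reports. "The series", "measured", "known", "first", "only" and "open" are said of these compounds alone.

Compound 2 `COc1cc2nc(N3CCCC3)nc(NS(=O)(=O)C3CC3)c2cc1OC` was measured in a functional assay on SK-OV-3 cells (Homo sapiens) for cytotoxicity, read by MTT assay, with a stated time of 24 h (a lower number here means a stronger inhibitor, a higher number a weaker inhibitor), and gave 17.6 ug/mL. Compound 1 `COc1cc2nc(Cl)nc(NS(=O)(=O)c3ccccc3)c2cc1OC` gave 9.23 ug/mL, and compound 3 `COc1cc2nc(Cl)nc(NS(=O)(=O)c3cccc(C(F)(F)F)c3)c2cc1OC` gave 32.3 ug/mL; the number for compound 2 lies within the usual scatter of both. The only single step among these, a 3.5-fold higher number from compound 1 to compound 3 (0.54 log units; beyond the scatter), concerns a different position and does not directly test the change at hand. Compound 4 `COc1cc2nc(N3CCCC3)nc(NS(=O)(=O)c3ccc(C)cc3)c2cc1OC` differs from compound 2 by 4-methylphenyl in place of cyclopropyl on a sulfonyl sulfur. Compound 1, which also carries an aromatic ring on the sulfonyl sulfur, gives 9.23 ug/mL, so a number near compound 2, perhaps somewhat lower, is expected. Compound 4 is therefore estimated at 12 ug/mL, within 5 ug/mL to 30 ug/mL, a step of a 1.5-fold lower number from compound 2 to compound 4 (0.17 log units; within the scatter) expected to stay within the scatter.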

Compound 4, half-maximal inhibitory concentration: 20 ug/mL
The estimate for compound 4 lay 1.7-fold (0.22 log units) below the measured number, and the stated range covers the measured number.
By their numbers in this assay, from the lowest: compounds 1, 2, 4 and 3 (each within the scatter of the next, the first and the last beyond it).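

In this assay, within the data shown here, the change to 4-methylphenyl in place of cyclopropyl on a sulfonyl sulfur gives a 1.1-fold higher number from compound 2 to compound 4 (0.06 log units; within the scatter) and so offers the first direct reading at this position. With the rest of the structure held constant, the aromatic ring and the three-membered non-aromatic ring cannot be told apart in this assay. No measurement shown here offers an explanation for this result.

Going by these compounds, whether an amine or a longer alkyl chain on the sulfonyl sulfur would give a step beyond the scatter remains open. So does whether a phenyl without the methyl would read the same on this core.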